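Varying the sulfur-linked group: compounds 1 to 3

The compounds below may be only part of what the source reports. "The series", "measured", "known", "first", "only" and "open" are said of these compounds alone.

Measured so far in a functional assay on L1210 cells (Mus musculus) for inhibition, read by thymidine incorporation; a higher number here means that more compound is needed for the effect, a lower number that less compound is needed:
- compound 1, `CSc1nc(N)nc2c1ncn2[C@@H]1C[C@H](O)[C@@H](CO)O1`: > 100 uM
- compound 2, `C=CCSc1nc(N)nc2c1ncn2[C@@H]1C[C@H](O)[C@@H](CO)O1`: > 100 uM

Compound 1 does not reach a half-maximal effect within the tested range in this assay, and its value > 100 uM is a limit, not a number. Compound 2 likewise yields only a limit in this assay, > 100 uM. The step that the two limits leave unreadable from compound 1 to compound 2 is accordingly unreadable: both of its ends are limits. What the series shows so far is the limit of > 100 uM in this assay, at which 2 of the 2 values shown sit, and it says no more than that neither compound shows a measurable effect.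

Compound 3, `Cc1cccc(CSc2nc(N)nc3c2ncn3[C@@H]2C[C@H](O)[C@@H](CO)O2)n1`, differs from compound 2 by 6-methylpyridin-2-yl in place of vinyl on a saturated chain carbon bound to a sulfur. Going by the values given here, no measured step of readable size bears on this change; the only step available, from compound 1 to compound 2, gives no direction and no magnitude. With compound 2 standing at the limit, the expectation for compound 3 is a value that again sits at or beyond that limit, an estimated step that the limit leaves unreadable from compound 2 to compound 3. Compound 3 is therefore estimated at 150 uM in this assay, with a range from 30 uM to 600 uM.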

Compound 3, concentration for half-maximal effect: 79 uM
Estimate against measurement, compound 3: 1.9-fold (0.28 log units) above, and the stated range covers the measured number.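

Going by these compounds alone, compound 3 is the only compound of the three to give a number rather than a limit in this assay, at 79 uM, so this position on the sulfur-linked chain accepts a group with an aromatic ring while the effect comes within the tested range. Placing 6-methylpyridin-2-yl on a saturated chain carbon bound to a sulfur gives an at least 1.2-fold lower number from compound 2 to compound 3 (0.10 log units; that floor lies within the scatter) when it replaces vinyl, and an at least 1.2-fold lower number from compound 1 to compound 3 (0.10 log units; that floor lies within the scatter) when it replaces hydrogen; both sizes are floors, and neither shows by itself a change larger than the scatter. The readable value therefore stands close to a limit that still holds compound 1 and compound 2: the limit of > 100 uM in this assay, at which 2 of the 3 values shown sit.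

Open, on these data alone, is which part of the entering group matters, the ring nitrogen or the methyl, and whether a plain benzyl or an unsubstituted pyridin-2-ylmethyl on the sulfur would read the same. Also open, as far as these compounds go, is how a longer chain between sulfur and ring, or an amine or a carboxylic acid on that ring, would move the number.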